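A Sulfonyl Swap on a Scaffold Without Measured Toxicity

A few compounds are considered here, and "the series" means these few. Any claim that something is new, unique, unknown or untested is made for them only; others in the source may bear on it.

Two compounds built on one shared core have been examined in a functional assay on HEK293 cells (Homo sapiens) for cytotoxicity; on this read-out higher numbers stand for lower toxicity in this test and lower numbers for higher toxicity in this test. Compound 1, `COc1ccc([C@H]2CC(=O)N(c3ccc(N)cc3)C2)cc1OC1CCCC1`, reaches only the ceiling of this test: in this assay compound 1 gives > 10000 nM, which is a limit of the assay and not a number. Compound 2, `COc1ccc([C@H]2CC(=O)N(c3cccc(NCCCc4ccccc4)c3)C2)cc1OC1CCCC1`, behaves the same way; in this assay compound 2 gives > 10000 nM, again a limit rather than a measured value. Compound 2 therefore stands exactly at the limit of > 10000 nM in this assay, at which 2 of the 2 values shown sit, and no ordering between the two compounds can be read from this.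

Compound 3, `COc1ccc([C@H]2CC(=O)N(c3cccc(NS(=O)(=O)c4ccccc4F)c3)C2)cc1OC1CCCC1`, is the new member and differs from compound 2 in a single place: (2-fluorophenyl)sulfonyl in place of 3-phenylpropyl on a nitrogen on an aromatic ring. Going by the values given here, no step between two measured compounds is available, so nothing in the data says how large a change of this kind moves the read-out, nor in which direction. Given that compound 2 sits at the limit, compound 3 is expected to stay there as well, a step that the limit leaves unreadable from compound 2 to compound 3, with an estimated value for compound 3 of 15000 nM within a range from 5000 nM to 50000 nM.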

Compound 3, half-maximal cytotoxic concentration: > 10000 nM
Compound 3 ended at the assay's limit (the forecaster's own chance of this, stated with the estimate: 80%); the middle value does not contradict the limit.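

In this assay compound 3 gives > 10000 nM, which is a limit of the assay and not a number. No step from compound 2 to compound 3 can be read, because all the compounds shown sit at the same limit: the limit of > 10000 nM in this assay, at which 3 of the 3 values shown sit.

The compounds shown leave open whether any change on the shared core moves this read-out to a measurable value.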